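Swapping a ring-bearing group for a short chain

The source may report more compounds than this note shows. Statements on the series, on what has been measured and on what is new or still open speak of the compounds shown alone.

Measured so far:
compound 1 `Cc1cc(C)c(CN2CCc3c(Cl)cc([C@H](CO)[C@H]4CCOC4)c(Cl)c3C2=O)c(=O)[nH]1` gives 570000 nM
compound 2 `Cc1cc(C)c(CN2CCc3c(Cl)cc([C@H](CO)[C@H]4CCCO4)c(Cl)c3C2=O)c(=O)[nH]1` gives 430000 nM
compound 3 `Cc1cc(C)c(CN2CCc3c(Cl)cc(C(CO)c4ccon4)c(Cl)c3C2=O)c(=O)[nH]1` gives 596000 nM; 481000 nM (2 entries)

In a physicochemical assay for solubility, measured as kinetic solubility (on this read-out lower numbers stand for lower solubility and higher numbers for higher solubility), compound 2 reads 430000 nM and cannot be told apart from compound 1: the exchange of oxolan-3-yl for oxolan-2-yl gave a 1.3-fold lower number from compound 1 to compound 2 (0.12 log units; within the scatter) and nothing more. Repeat readings also matter here, and the several entries of compound 3 in this assay, 596000 nM; 481000 nM (2 entries) show how far two readings of one compound can lie apart.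

Compound 4 `Cc1cc(C)c(CN2CCc3c(Cl)cc([C@H](C)CO)c(Cl)c3C2=O)c(=O)[nH]1` has not yet been measured. It departs from compound 2 by a larger change, a group of 4 heavy atoms (3 carbon, 1 oxygen; no ring) in place of a group of 8 heavy atoms (6 carbon, 2 oxygen; one five-membered non-aromatic ring with 1 hetero atom), on an aromatic carbon in the shared core. What enters is 1-(hydroxymethyl)ethyl, which has no ring, while the five-membered non-aromatic ring leaves.

Within the data shown here, no measured step tests the loss of that ring, and the single step available keeps a ring in place, so it is only a weak guide. Still, with a 1.3-fold lower number from compound 1 to compound 2 (0.12 log units; within the scatter) as the one size available, no change beyond the scatter is expected in this assay and no direction can be argued. The estimated move is a 1.1-fold higher number from compound 2 to compound 4 (0.05 log units; within the scatter) under this expectation. For compound 4 the expected value is 480000 nM with an estimated range from 250000 nM to 750000 nM around it.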

Compound 4, solubility: 131000 nM
Compound 4: the middle estimate sits 3.7-fold (0.56 log units) above what was measured; measured number below the stated range.
By their numbers in this assay, from the lowest: compound 4; then compounds 2 and 1 (each within the scatter of the next).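

In this assay, this aromatic carbon of the shared core proves sensitive to what it carries: putting 1-(hydroxymethyl)ethyl in place of the group with the oxolan-2-yl ring gives a 3.3-fold lower number from compound 2 to compound 4 (0.52 log units; beyond the scatter), and the same kind of exchange starting from the oxolan-3-yl ring gives a 4.4-fold lower number from compound 1 to compound 4 (0.64 log units; beyond the scatter). Both steps lie beyond the scatter, whereas exchanging one oxolane attachment for the other stayed within it, so among these compounds the choice between the two rings matters less than whether the larger ring-bearing group is present at all. Each step is also wider than the gap between two readings of a single compound: the several entries of compound 3 in this assay, 596000 nM; 481000 nM (2 entries)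

As far as these compounds go, what remains open is whether the ring itself matters or simply the extra atoms that leave with it, since this change removes both together. A longer open chain carrying an ether oxygen would separate those two readings, and a group holding an amine at the same carbon would show how far the number can move with a different kind of substituent.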